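A few compounds are considered here, and "the series" means these few. Any claim that something is new, unique, unknown or untested is made for them only; others in the source may bear on it.

Working notes on cytotoxicity in the series. In a toxicity assay on NIH3T3 cells (Mus musculus) for cytotoxicity, read by resazurin assay (a lower number here means that less compound is needed, a higher number that more compound is needed for the effect), compound 1 `O=C(OC1CCCCC1)c1ccc(NCc2cncn2Cc2ccc(-c3ccccc3)cc2)cc1-c1ccccc1` gives only a limit, > 10000 nM. Compound 2 `Cc1ccccc1-c1cccc(NCc2cncn2Cc2ccccc2)c1` likewise returns only a limit in this assay, > 1000 nM. Both readings are limits rather than numbers, one being the limit of > 10000 nM in this assay, at which 1 of the 2 values shown sits, and the other (the limit of > 1000 nM in this assay, at which 1 of the 2 values shown sits), so compound 1 and compound 2 cannot be ordered against each other. Compound 3 `CNC(=O)c1ccc(NCc2cncn2Cc2ccc(-c3ccccc3)cc2)cc1-c1ccccc1` awaits measurement; against compound 1 it shows (methylamino in place of cyclohexyloxy on a carbonyl carbon). Going by the values given here, with no measured step of this kind available, no shift beyond the scatter is expected. The step expected in this assay is a number no higher from compound 1 to compound 3 (the limit leaves the size open). Compound 3 is estimated at 10000 nM, within 3000 nM to 30000 nM.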

Compound 3, half-maximal effective concentration: > 1000 nM
Compound 3 gave a limit, no number (the forecaster's own chance of this, stated with the estimate: 80%); the middle value lies beyond the limit too.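

Going by these compounds alone, compound 1 and compound 3 both return only limits in this assay, so no step between them can be read. The compounds shown leave open whether methylamino in place of cyclohexyloxy on a carbonyl carbon shifts the reading at all.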